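Ring swap at the ether of compound 3

The compounds below may be only part of what the source reports. "The series", "measured", "known", "first", "only" and "open" are said of these compounds alone.

Measured so far:
compound 1 `Nc1ccc2cccc(OCCC(F)(F)F)c2n1` — 722 nM
compound 2 `Nc1ccc2cccc(OCC3CCOC3)c2n1` — 115 nM
compound 3 `CC1CC1COc1cccc2ccc(N)nc12` — 1640 nM

All three compounds share one core and differ only in the group on a saturated chain carbon bound to an oxygen on an aromatic ring. In an assay on cells with melanin-concentrating hormone receptor 1 (Homo sapiens) as the target, read by radioligand binding (a lower number here means a stronger inhibitor, a higher number a weaker inhibitor), compound 3 gives 1640 nM, the highest number of the three: the step of a 2.3-fold higher number from compound 1 to compound 3 (0.36 log units; beyond the scatter) is modest, while the step of a 14-fold higher number from compound 2 to compound 3 (1.15 log units; beyond the scatter) is large, so compound 3 sits well behind compound 2 and somewhat behind compound 1 in this assay.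

Compound 4 `Nc1ccc2cccc(OCC3CCC3)c2n1` has not yet been measured in this assay. It differs from compound 3 by cyclobutyl in place of 2-methylcyclopropyl on a saturated chain carbon bound to an oxygen on an aromatic ring. Among the compounds with values here, no measured pair carries this particular change, so the steps that bear on it only frame the ether substituent as a sensitive position: the modest step of a 2.3-fold higher number from compound 1 to compound 3 (0.36 log units; beyond the scatter) and the large step of a 14-fold higher number from compound 2 to compound 3 (1.15 log units; beyond the scatter). A four-membered ring of carbon only replacing a three-membered ring of carbon only with its methyl is a smaller rearrangement than either of those, and the expected step of a 1.5-fold lower number from compound 3 to compound 4 (0.17 log units; within the scatter) is therefore judged to be small and likely within the scatter. Compound 4 is estimated to give 1100 nM, with an expected range from 400 nM to 3000 nM.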

Compound 4, half-maximal inhibitory concentration: 432 nM
The estimate for compound 4 lay 2.5-fold (0.41 log units) above the measured number, and the stated range covers the measured number.
By their numbers in this assay, from the lowest: compound 2; then compounds 4 and 1 (each within the scatter of the next); then compound 3.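

In this assay, rearranging the same atoms from 2-methylcyclopropyl to cyclobutyl is enough to move the number by more than the scatter (a 3.8-fold lower number from compound 3 to compound 4 (0.58 log units; beyond the scatter)), so these two carbon-only rings are not interchangeable at this place. Cyclobutyl still falls short of oxolan-3-yl (a 3.8-fold higher number from compound 2 to compound 4 (0.57 log units; beyond the scatter)), which leaves compound 2 with the lowest number of the four, beyond the scatter of each of the others. Set against 2,2,2-trifluoroethyl, cyclobutyl cannot be told apart (a 1.7-fold lower number from compound 1 to compound 4 (0.22 log units; within the scatter)), and compounds 2, 3 and 4 all carry a ring yet are spread apart, so a ring on this chain carbon does not by itself set the number.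

No evidence is available that accounts for any of these differences. The compounds shown leave open whether the gap between compound 3 and compound 4 follows ring size or the methyl group, which a plain cyclopropyl group would help separate, and whether the advantage of compound 2 depends on its ring oxygen, which a cyclopentyl group would test directly.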